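The source may report more compounds than this note shows. Statements on the series, on what has been measured and on what is new or still open speak of the compounds shown alone.

Working notes on the series, read-out an ADME assay on microsomes from liver (Canis lupus familiaris) for metabolic stability; on this read-out lower numbers stand for a shorter-lived compound and higher numbers for a longer-lived compound. Compound 1 (`Nc1nc(NCCNc2ncc(-c3ncc[nH]3)c(-c3ccc(Cl)cc3)n2)ccc1[N+](=O)[O-]`) gives > 0.5 h, which is a limit and not a number. Compound 2 (`Nc1nc(NCCNc2ncc(-c3ncc[nH]3)c(-c3cc(F)ccc3F)n2)ccc1[N+](=O)[O-]`) gives > 0.5 h, which is also a limit. The record therefore holds only (the limit of > 0.5 h in this assay, at which 2 of the 2 values shown sit), and compound 1 offers no exact starting value.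

The change under review leads from compound 1 to compound 3 (`Nc1nc(NCCNc2ncc(-c3ncc[nH]3)c(-c3cc(F)c(F)cc3F)n2)ccc1[N+](=O)[O-]`), with 2,4,5-trifluorophenyl in place of 4-chlorophenyl on an aromatic carbon.

Among the measured compounds shown here, the one measured step that bears on this change is a step that the two limits leave unreadable from compound 1 to compound 2, with 2,5-difluorophenyl in place of 4-chlorophenyl on an aromatic carbon. That step sets no size, so only a step within the scatter is expected in this assay, and no direction can be assigned. The step expected is a step that the limit leaves unreadable from compound 1 to compound 3. A report of a limit is also expected to be the likely outcome for compound 3.

The estimate for compound 3 is 0.7 h, with an expected range from 0.4 h to 1.5 h.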

Compound 3, half-life: > 0.5 h
Compound 3 ended at the assay's limit; the forecaster's own chance of this, stated with the estimate: 75%; the middle value lies beyond the limit too.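

In this assay, compound 3 reports a limit, as do compound 1 and compound 2, so no step among these three compounds can be read: the limit of > 0.5 h in this assay, at which 3 of the 3 values shown sit. The compounds shown leave open the actual half-life of each compound and whether 4-chlorophenyl, 2,5-difluorophenyl and 2,4,5-trifluorophenyl differ at all on this read-out.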